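Substituent swap on the ring nitrogen of compound 2

This account rests on a few compounds, and the source may have more. Where it says the series, first, only, none or still open, it means among the compounds named here.

Measured compounds:
compound 1 `CN(CCNCc1cn(-c2ccccc2)nn1)CCNc1ccnc2cc(Cl)ccc12`: 10000 nM
compound 2 `CN(CCNCc1cn(-c2cccc(Cl)c2)nn1)CCNc1ccnc2cc(Cl)ccc12`: 12000 nM
compound 3 `CN(CCNCc1cn(Cc2ccc(Br)cc2)nn1)CCNc1ccnc2cc(Cl)ccc12`: 8700 nM

All three were tested in a functional assay on BXPC-3 cells (Homo sapiens) for antiproliferative activity, read by sulforhodamine B assay, with a stated time of 72 h; on this read-out higher numbers stand for weaker inhibition and lower numbers for stronger inhibition. Compound 2 shows the highest number of the three, but its separation from compound 1 is only a 1.2-fold higher number from compound 1 to compound 2 (0.08 log units; within the scatter) and from compound 3 only a 1.4-fold lower number from compound 2 to compound 3 (0.14 log units; within the scatter), so the three numbers are indistinguishable on this assay.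

Compound 4 `CN(CCNCc1cn(-c2nc3ccccc3[nH]2)nn1)CCNc1ccnc2cc(Cl)ccc12` is not yet measured. It differs from compound 2 in one place: 1H-benzimidazol-2-yl in place of 3-chlorophenyl on an aromatic nitrogen. Two measured steps change the group on the same aromatic nitrogen. From compound 1 to compound 3 the step is a 1.1-fold lower number from compound 1 to compound 3 (0.06 log units; within the scatter), and from compound 2 to compound 3 it is a 1.4-fold lower number from compound 2 to compound 3 (0.14 log units; within the scatter). Neither exceeds the scatter, so exchanging the group on that nitrogen has so far left this assay unchanged. Within the data shown here, no step yet brings in a hydrogen-bond donor at that position, so the outcome for 1H-benzimidazol-2-yl is uncertain, but the expectation is no step beyond the scatter. Compound 4 is therefore estimated at 10000 nM, within a range from 4000 nM to 25000 nM. That amounts to an expected step of a 1.2-fold lower number from compound 2 to compound 4 (0.08 log units; within the scatter).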

Compound 4, half-maximal inhibitory concentration: 16000 nM
Compound 4: the middle estimate sits 1.6-fold (0.20 log units) below what was measured, and the stated range covers the measured number.
By their numbers in this assay, from the lowest: compounds 3, 1, 2 and 4 (each within the scatter of the next).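

In this assay, 1H-benzimidazol-2-yl on the aromatic nitrogen gives a 1.3-fold higher number from compound 2 to compound 4 (0.12 log units; within the scatter) and a 1.6-fold higher number from compound 1 to compound 4 (0.20 log units; within the scatter) and a 1.8-fold higher number from compound 3 to compound 4 (0.26 log units; within the scatter). The insensitivity seen among phenyl, 3-chlorophenyl and 4-bromobenzyl therefore extends to a group with a hydrogen-bond donor and a five-membered aromatic ring fused to the six-membered one, so this position has not separated any of the four compounds. No measurement available here accounts for this lack of separation.

Open, from the compounds shown here alone, is whether a carboxylic acid or an amine on the group at this nitrogen, or a longer chain in place of the 4-bromobenzyl link, would give a step beyond the scatter. Also open, going by these compounds, is whether changes to the shared core would move the numbers in this assay when this position does not.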